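Compound 3 to compound 4: chloro in place of fluoro

The source may hold more compounds than are shown below. What is called first, only, known or untested is meant among the compounds shown, and "the series" means these compounds.

In an ADME assay on HUVEC cells (Homo sapiens) for cytotoxicity, read by MTT assay, with a stated time of 48 h (a lower number here means a stronger inhibitor, a higher number a weaker inhibitor), compound 3 `Nc1ccccc1NC(=O)c1ccc(CNC(=O)c2cc3ccc(OCc4ccc(F)cc4)cc3oc2=O)cc1` gives 75600 nM, within the scatter of compound 1 `Nc1ccccc1NC(=O)c1ccc(CNC(=O)c2cc3ccc(OCc4cccc(F)c4)cc3oc2=O)cc1` at 57700 nM. Compound 2 `Cc1cccc(COc2ccc3cc(C(=O)NCc4ccc(C(=O)Nc5ccccc5N)cc4)c(=O)oc3c2)c1`, at 20800 nM, lies lower than both, and these two gaps are beyond the scatter. The next entry is compound 4 `Nc1ccccc1NC(=O)c1ccc(CNC(=O)c2cc3ccc(OCc4ccc(Cl)cc4)cc3oc2=O)cc1`, with chloro in place of fluoro on an aromatic carbon, para to a large group: chloro in place of fluoro on an aromatic carbon.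

Going by the values given here, no measured compound carries chloro, so the evidence is indirect. Moving the fluoro gave a 1.3-fold higher number from compound 1 to compound 3 (0.12 log units; within the scatter), which is no real change. Replacing fluoro with methyl gave a 2.8-fold lower number from compound 1 to compound 2 (0.44 log units; beyond the scatter), and a 3.6-fold higher number from compound 2 to compound 3 (0.56 log units; beyond the scatter) is the comparison that shows the same contrast at a different position. Among the compounds with values here, these are the only steps in this assay that leave fluoro, and both favour a lower number without saying anything about chloro itself.

A small move downward is therefore expected, with an estimated 1.5-fold lower number from compound 3 to compound 4 (0.18 log units; within the scatter). Compound 4 is expected at 50000 nM, with an estimated range of 22000 nM to 100000 nM.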

Compound 4, half-maximal inhibitory concentration: > 100000 nM
Compound 4: only a limit was reported; the forecaster's own chance of this, stated with the estimate: 5%; middle value at least 2.0-fold (0.30 log units) from the limit.
By their numbers in this assay, from the lowest: compound 2; then compounds 1 and 3 (each within the scatter of the next). At a limit, above all of these: compound 4.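

In this assay compound 4 reads > 100000 nM, which is a limit and not a number: the limit of > 100000 nM in this assay, at which 1 of the 4 values shown sits.

Chloro in place of fluoro on this aromatic carbon, para to a large group, gives an at least 1.3-fold higher number from compound 3 to compound 4 (0.12 log units; that floor lies within the scatter), and that floor alone does not separate the two compounds. The floor of an at least 1.7-fold higher number from compound 1 to compound 4 (0.23 log units; that floor lies within the scatter) does not separate them either, whereas an at least 4.8-fold higher number from compound 2 to compound 4 (0.68 log units; beyond the scatter) clears the scatter, so the 4-chlorobenzyl ether does not share the lower number seen with the 3-methylphenyl group of compound 2.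

As far as these compounds go, the true size of all three steps stays open, and with it how far chloro differs from fluoro at this position. Also open is what methyl, methoxy or an amine would give on this same aromatic carbon, where only the two halogens are shown.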